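The source may hold more compounds than are shown below. What is called first, only, known or untested is meant among the compounds shown, and "the series" means these compounds.

Three compounds share one core, in which a sulfonamide and an amide hang from the same central ring. In an assay on MDA-MB-231 cells for binding affinity to C-X-C chemokine receptor type 4 (Homo sapiens), read by fluorescence and microscopy, with stated times of 10 min and 30 min (on this read-out lower numbers stand for an effect already at smaller amounts and higher numbers for an effect only at larger amounts of compound), compound 1 `Cc1ccc(S(=O)(=O)NCc2ccc(CNC(=O)c3ccc(F)nc3)cc2)cc1` reaches only the limit of the assay, > 1000 nM. In this assay compound 2 `Cc1ccc(S(=O)(=O)NCc2ccc(CNC(=O)c3ccc(F)cn3)cc2)cc1` gives 1000 nM. Compound 3 `O=C(NCc1ccc(CNS(=O)(=O)c2ccc(Cl)cc2)cc1)c1ccc(F)cc1` gives 100 nM in this assay, the lower of the two numbers shown. Within the data shown here, the one measured step, a number no higher from compound 1 to compound 2 (the limit leaves the size open), concerns the amide side; its size cannot be read because compound 1 sits at the limit (the limit of > 1000 nM in this assay, at which 1 of the 3 values shown sits).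

Compound 4 `O=C(NCc1ccc(CNS(=O)(=O)c2ccc(F)c(F)c2)cc1)c1ccc(F)cc1` has not yet been measured. It differs from compound 3 only on the sulfonyl side: 3,4-difluorophenyl in place of 4-chlorophenyl on a sulfonyl sulfur. Among the measured compounds shown here, no measured step touches that side, so no direction is suggested, and any change is expected to stay within the scatter. Compound 4 is therefore expected to give 150 nM, between 50 nM and 500 nM, a step of a 1.5-fold higher number from compound 3 to compound 4 (0.18 log units; within the scatter).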

Compound 4, effective concentration (reported as EC, without a stated level of effect): 10 nM
For compound 4 the middle estimate is 15-fold (1.18 log units) above the measured one, outside the stated range (below it).
By their numbers in this assay, from the lowest: compound 4; then compound 3; then compound 2.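

Among these compounds, the sulfonyl side, which no earlier step touched, can clearly move the number: in this assay there is a 10-fold lower number from compound 3 to compound 4 (1.00 log units; beyond the scatter) when 3,4-difluorophenyl replaces 4-chlorophenyl on the sulfonyl sulfur. Both groups are one six-membered aromatic ring of carbon only with no net charge, so they differ only in their halogens. Nothing shown here accounts for this step.

On these data alone, it remains open how a phenyl ring carrying an amine or a carboxylic acid would behave on this sulfonyl sulfur. As far as these compounds go, it is also open whether the same exchange would lower the number with the 5-fluoropyridin-2-yl amide of compound 2.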